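The compounds below may be only part of what the source reports. "The series", "measured", "known", "first", "only" and "open" are said of these compounds alone.

Measured compounds and their values in a functional assay on MV cells (Homo sapiens) for inhibition, read by sulforhodamine B assay; a lower number here means a stronger inhibitor, a higher number a weaker inhibitor:
- compound 2 `C#CC(=O)N1C(CCCC)SC[C@@H]1C(=O)OCC`: 400 nM
- compound 1 `C#CC(=O)N1C(c2cccc(F)c2)SC[C@@H]1C(=O)OCC`: 1700 nM

For the measured compounds named here, compound 2 carries the lowest number of the two; its nearest neighbour is compound 1, and the single one-place step runs a 4.3-fold lower number from compound 1 to compound 2 (0.63 log units; beyond the scatter), a butyl in place of a 3-fluorophenyl on a saturated ring carbon.

Compound 3 `C#CC(=O)N1C(C(C)CCC)SC[C@@H]1C(=O)OCC` is not yet measured. It differs from compound 2 by methyl in place of hydrogen on a saturated chain carbon bound to a saturated chain carbon and a saturated ring carbon, which read one bond further out is butyl to 1-methylbutyl.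

Going by the values given here, no measured step concerns a methyl added to the chain; the only step available, from the 3-fluorophenyl to the butyl, changes a different part of the substituent and gives no direction for this branching. The working expectation for compound 3 is therefore a step of no change at the digits printed from compound 2 to compound 3 (within the scatter), within the scatter. In this assay compound 3 is estimated at 400 nM, with a range from 150 nM to 1100 nM.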

Compound 3, half-maximal inhibitory concentration: 500 nM
For compound 3 the middle estimate is 1.3-fold (0.10 log units) below the measured one, within the range that was stated.
By their numbers in this assay, from the lowest: compounds 2 and 3 (each within the scatter of the next); then compound 1.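

In this assay, branching the chain at the carbon bound to the saturated ring carbon leaves the number within the scatter of the butyl compound (a 1.3-fold higher number from compound 2 to compound 3 (0.10 log units; within the scatter)), so this position accepts the added methyl, at least in this single case. The 1-methylbutyl group also stands clear of the 3-fluorophenyl group (a 3.4-fold lower number from compound 1 to compound 3 (0.53 log units; beyond the scatter)), so compounds 2 and 3, the two open-chain members, both carry lower numbers than the aryl compound 1. No measurement on hand accounts for either step.

Still open, going by these compounds, is how far the chain can be extended or branched, for instance with a hexyl or a tert-butyl group. Also open, on these data alone, is whether an amine or a carboxylic acid at the end of the butyl chain would be accepted.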